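The source may hold more compounds than are shown below. What is called first, only, known or untested is meant among the compounds shown, and "the series" means these compounds.

Measured so far in a functional assay on HeLa cells (Homo sapiens) for antiproliferative activity, read by CCK-8 assay, with a stated time of 72 h; a lower number here means a stronger inhibitor, a higher number a weaker inhibitor:

- compound 1 `CCOC(=O)Oc1cc(-c2cncnc2-c2cc(OC)c(OC)c(OC)c2)ccc1OC` gives 650 nM in this test
- compound 2 `COc1ccc(-c2cncnc2-c2cc(OC)c(OC)c(OC)c2)cc1F` gives 500 nM in this test

Compound 2 has the lowest of these two numbers, but the gap to compound 1 is within the usual scatter, so the pair cannot be ranked. The next molecule is compound 3 `CCOc1ccc(-c2cncnc2-c2cc(OC)c(OC)c(OC)c2)cc1`, which has 4-ethoxyphenyl in place of 3-fluoro-4-methoxyphenyl on an aromatic carbon of the shared core.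

Among the compounds with values here, only one measured step bears on this change: a 1.3-fold lower number from compound 1 to compound 2 (0.11 log units; within the scatter), where fluoro replaced (ethoxycarbonyl)oxy. Within the data shown here, that swap barely moved the number, but it is weak guidance, since no measured compound carries 4-ethoxyphenyl. Going by these compounds, no shift beyond the scatter is therefore expected in this assay, and either direction remains open. The estimated change is a 1.1-fold lower number from compound 2 to compound 3 (0.05 log units; within the scatter) in size. For compound 3 the expected value is 450 nM, within an estimated range of 120 nM to 1600 nM overall.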

Compound 3, half-maximal inhibitory concentration: 250 nM
For compound 3 the middle estimate is 1.8-fold (0.26 log units) above the measured one; measured number inside the range.
By their numbers in this assay, from the lowest: compounds 3, 2 and 1 (each within the scatter of the next, the first and the last beyond it).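

In this assay, putting 4-ethoxyphenyl in place of 3-fluoro-4-methoxyphenyl gives a 2.0-fold lower number from compound 2 to compound 3 (0.30 log units; within the scatter), so compound 2 and compound 3 cannot be ranked. Within the data shown here, compound 1 and compound 2 each carry a methoxy group and a second group on this phenyl ring, whereas compound 3 shows that a phenyl ring with ethoxy as its only group, on this aromatic carbon ortho to a large group, still gives a number of the same order. Nothing measured here explains this result.

The compounds shown leave open how a longer chain, such as butoxy, would fare on this ring. They also leave open whether an amine or a carboxylic acid in place of ethoxy would keep the number in this range.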